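A few compounds are considered here, and "the series" means these few. Any claim that something is new, unique, unknown or untested is made for them only; others in the source may bear on it.

Compound 1 `CN(C)CCn1cnnc1-c1cc(Oc2ccc(NC(=O)N/N=C/c3ccc(Cl)cc3Cl)cc2F)ccn1` gives 130 nM in a functional assay on NCI-H460 cells (Homo sapiens) for cytotoxicity, read by MTT assay, with a stated time of 72 h; a lower number here means a stronger inhibitor, a higher number a weaker inhibitor.
Compound 2 `CN(C)CCn1cnnc1-c1cc(Oc2ccc(NC(=O)N/N=C/c3c(Cl)cccc3Cl)cc2F)ccn1` gives 350 nM in this assay.

Compound 2 stands highest of the two numbers; its nearest neighbour is compound 1, separated from it by a 2.7-fold higher number from compound 1 to compound 2 (0.43 log units; beyond the scatter). Compound 3 `CN(C)CCn1cnnc1-c1cc(Oc2ccc(NC(=O)N/N=C/c3ccccc3)cc2F)ccn1` differs from compound 2 by phenyl in place of 2,6-dichlorophenyl on a carbon with a double bond to nitrogen. Among the compounds with values here, the single measured step only moves the two chlorines around the ring and does not bear directly on removing both, so the data give no direction for this change. Compound 3 is therefore expected to show only a small step, a 1.3-fold higher number from compound 2 to compound 3 (0.11 log units; within the scatter). Compound 3 is estimated at 450 nM in this assay, within 150 nM to 1400 nM.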

Compound 3, half-maximal inhibitory concentration: 1780 nM
Beside the measured number, compound 3's estimate is 4.0-fold (0.60 log units) below it, outside the stated range (above it).
By their numbers in this assay, from the lowest: compound 1; then compound 2; then compound 3.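

In this assay, taking both chlorines off the ring costs more than moving them: there is a 5.1-fold higher number from compound 2 to compound 3 (0.71 log units; beyond the scatter), and a 14-fold higher number from compound 1 to compound 3 (1.14 log units; beyond the scatter). Both dichlorophenyl compounds thus give lower numbers than the phenyl compound 3, so at this position on the carbon with a double bond to nitrogen, the chlorines count for more than their arrangement across these three compounds. Nothing available explains why this is so. From the compounds shown here alone, it remains open whether a monochlorophenyl group would keep the lower numbers, and whether a methoxyphenyl or trifluoromethylphenyl group could stand in for the dichlorophenyl groups.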